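A few compounds are considered here, and "the series" means these few. Any claim that something is new, unique, unknown or untested is made for them only; others in the source may bear on it.

In a functional assay on MDA-MB-435S cells (Homo sapiens) for antiproliferative activity, read by MTT assay, with a stated time of 72 h (a lower number here means a stronger inhibitor, a higher number a weaker inhibitor), compound 1 `Cc1nnc(Sc2coc3ccccc3c2=O)s1` gives > 50000 nM, which is a limit of the assay and not a number. Compound 2 `O=c1c(Sc2nc3ccccc3[nH]2)coc2ccccc12` gives 30300 nM and compound 3 `CN1CCN(/C=C2\Oc3ccccc3C2=O)CC1` gives 40300 nM, two values within the scatter of each other. Compound 4 `CN1CCN(/C=C2\Oc3ccccc3C2=O)C(c2ccccc2)C1` carries phenyl in place of hydrogen on a saturated ring carbon of the ring of compound 3 (phenyl in place of hydrogen on a saturated ring carbon). Within the data shown here, no measured pair shows what such a change does in this assay. Starting from compound 3 at 40300 nM, a modest move to a lower number is expected, close to the edge of the scatter. The expected size of this move is a 1.6-fold lower number from compound 3 to compound 4 (0.21 log units; within the scatter). The estimate for compound 4 is 25000 nM, with an expected range from 10000 nM to 50000 nM.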

Compound 4, half-maximal inhibitory concentration: > 50000 nM
Compound 4 gave a limit, no number; the forecaster's own chance of this, stated with the estimate: 25%; at least 2.0-fold (0.30 log units) between middle value and limit.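

Phenyl in place of hydrogen on a saturated ring carbon, next to the ring nitrogen, is the only single-place change shown, and in this assay it gives an at least 1.2-fold higher number from compound 3 to compound 4 (0.09 log units; that floor lies within the scatter). Compound 4 gives > 50000 nM, which is a limit of the assay and not a number, so no move to a lower number appears at this position and the true size of the step cannot be read. The reading is bounded by the top of the assay range: the limit of > 50000 nM in this assay, at which 2 of the 4 values shown sit.

Going by these compounds, whether a hydroxymethyl or aminomethyl group on this carbon would give a number under that limit remains open. So does the effect of phenyl on the other saturated ring carbons.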